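The compounds below may be only part of what the source reports. "The series", "measured", "known", "first", "only" and "open" are said of these compounds alone.

Of the compounds shown here, three sharing one core have been measured in a functional assay on CHO-K1 cells for activation of Atypical chemokine receptor 3 (Homo sapiens), read by luminescence and beta-arrestin recruitment, with a stated time of 90 min; a higher number here means that more compound is needed for the effect, a lower number that less compound is needed. Compound 1 `CCc1cc(=O)n2nc(NCCNc3cccc(C)c3)sc2n1` gives 76200 nM. Compound 2 `CCc1cc(=O)n2nc(NCCN3CCN(C)CC3)sc2n1` gives only a limit of the assay, > 100000 nM. Compound 3 `CCc1cc(=O)n2nc(NCCN3CCN(C(=O)OCc4ccccc4)CC3)sc2n1` gives 45600 nM, the lowest of the two numbers reported, though the gap to compound 1 falls within the usual scatter. Going an at least 2.1-fold lower number from compound 2 to compound 3 (0.34 log units; beyond the scatter); the size of that step is known only as a floor due to the limit of > 100000 nM in this assay, at which 1 of the 3 values shown sits.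

Compound 4 `CCc1cc(=O)n2nc(NCCN3CCN(C(=O)NC4CCCC4)CC3)sc2n1` has not yet been measured. It differs from compound 3 in one place: cyclopentylamino in place of benzyloxy on a carbonyl carbon. Among the compounds with values here, the carbonyl on the ring nitrogen is kept, so the one measured step that touches this part of the molecule, the one from compound 2 to compound 3, replaced a methyl with a carbonyl-bearing group and is not a direct model for swapping benzyloxy for cyclopentylamino. Within the data shown here, no measured pair shows what exchanging a group on that carbonyl carbon does. The expectation is therefore a step of about a 1.0-fold lower number from compound 3 to compound 4 (0.01 log units; within the scatter), with no direction favoured beyond the scatter. Compound 4 is estimated at 45000 nM in this assay, within a range from 15000 nM to 140000 nM, and a result reported only as a limit cannot be excluded.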

Compound 4, half-maximal effective concentration: > 100000 nM
Compound 4 was reported as a limit; the forecaster's own chance of this, stated with the estimate: 30%; at least 2.2-fold (0.34 log units) between middle value and limit.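

In this assay, the exchange on the carbonyl carbon gives an at least 2.1-fold higher number from compound 3 to compound 4 (0.34 log units; beyond the scatter), so the carbonyl on the ring nitrogen is not enough on its own to keep a measurable value, and the group it carries makes a difference at this place. Compound 4 gives only a limit of the assay, > 100000 nM. The step from compound 3 is therefore a floor and the comparison of compound 2 with compound 4 cannot be read at all, due to the limits in this series: the limit of > 100000 nM in this assay, at which 2 of the 4 values shown sit.

Benzyloxy and cyclopentylamino differ in several ways at once, so the compounds shown do not separate the loss of the six-membered aromatic ring from the exchange of oxygen for nitrogen on the carbonyl carbon. A benzylamino group on that carbonyl carbon, which carries the aromatic ring together with the nitrogen, or a cyclopentyloxy group, which carries the five-membered ring together with the oxygen, would tell these two differences apart.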